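The source may hold more compounds than are shown below. What is called first, only, known or untested is meant among the compounds shown, and "the series" means these compounds.

In a functional assay on DU-145 cells (Homo sapiens) for cytotoxicity (a higher number here means a weaker inhibitor of growth, a lower number a stronger inhibitor of growth), compound 1 `COc1ccc(C2=C(c3ccc(SC)cc3)CC3CCCN3C2=O)cc1O` gives 6000 nM. Compound 2 `COc1ccc(C2=C(c3ccc(SC)cc3)CC3CCCN3C2=O)cc1OC(=O)C1CCCN1C(=O)OC(C)(C)C` gives 5000 nM, within the scatter of compound 1, and these two share the high end of the numbers. Compound 3 `CSc1ccc(C2=C(c3ccc(F)c(F)c3)C(=O)N3CCCC3C2)cc1` gives 500 nM, well clear of both. Compound 4 `CSc1ccc(C2=C(c3ccc(F)c(C)c3)C(=O)N3CCCC3C2)cc1` differs from compound 1 in one place: 4-fluoro-3-methylphenyl in place of 3-hydroxy-4-methoxyphenyl on a double-bonded ring carbon. Within the data shown here, the one measured step that bears on this is a 12-fold lower number from compound 1 to compound 3 (1.08 log units; beyond the scatter), a large change at the same place, with 3,4-difluorophenyl as the entering group. Among the measured compounds shown here, no measured step shows what a methyl in place of a fluorine does, so a step of similar size towards a lower number is expected in this assay. The expected step is a 10-fold lower number from compound 1 to compound 4 (1.00 log units; beyond the scatter). For compound 4 the estimated value is 600 nM, with an expected range of 200 nM to 2000 nM.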

Compound 4, concentration for 50% growth inhibition: 500 nM
Compound 4: the middle estimate sits 1.2-fold (0.08 log units) above what was measured; the measured number falls inside the stated range.
By their numbers in this assay, from the lowest: compounds 3 and 4 (each within the scatter of the next); then compounds 2 and 1 (each within the scatter of the next).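

In this assay, the change from 3-hydroxy-4-methoxyphenyl to 4-fluoro-3-methylphenyl gives a 12-fold lower number from compound 1 to compound 4 (1.08 log units; beyond the scatter) and so repeats the large step seen with 3,4-difluorophenyl. This lower number therefore does not depend on 3,4-difluorophenyl alone, and methyl in place of fluoro gives no change at the digits printed from compound 3 to compound 4 (within the scatter) as well. No measurement on hand explains why either group lowers the number. From the compounds shown here alone, whether an amine or a carboxylic acid on this aromatic ring would keep the lower number remains open, as does the effect of a longer chain in place of the methyl.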